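The source may report more compounds than this note shows. Statements on the series, on what has been measured and on what is new or still open speak of the compounds shown alone.

Three imines built on one shared core were tested in an ADME assay on cells (Rhabdomyosarcoma cell, Homo sapiens) for cytotoxicity, read by MTT assay, with a stated time of 72 h; on this read-out higher numbers stand for lower toxicity in this test and lower numbers for higher toxicity in this test. Compound 1 `Clc1ccc(/C=N/c2sc3c(c2-c2nc4ccccc4s2)CCCC3)c(Cl)c1` gives 56.6 ug/mL, compound 2 `Clc1ccccc1/C=N/c1sc2c(c1-c1nc3ccccc3s1)CCCC2` gives 332 ug/mL, and compound 3 `O=[N+]([O-])c1ccccc1/C=N/c1sc2c(c1-c1nc3ccccc3s1)CCCC2` gives 255 ug/mL. Compound 3 therefore stands second highest of the three: its value and that of compound 2 lie within the scatter of each other, while it sits clearly apart from compound 1, as a 4.5-fold higher number from compound 1 to compound 3 (0.65 log units; beyond the scatter) shows. Compound 4 `FC(F)(F)c1ccc(/C=N/c2sc3c(c2-c2nc4ccccc4s2)CCCC3)cc1` differs from compound 3 by 4-(trifluoromethyl)phenyl in place of 2-nitrophenyl on a carbon with a double bond to nitrogen. For the measured compounds named here, the steps that bear on this change are a 4.5-fold higher number from compound 1 to compound 3 (0.65 log units; beyond the scatter) and a 5.9-fold higher number from compound 1 to compound 2 (0.77 log units; beyond the scatter), both modest, and a 1.3-fold lower number from compound 2 to compound 3 (0.11 log units; within the scatter), within the scatter. A step of modest size in either direction is thus expected, meaning a 1.7-fold lower number from compound 3 to compound 4 (0.23 log units; within the scatter). Compound 4 is estimated at 150 ug/mL, with a range from 50 ug/mL to 400 ug/mL.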

Compound 4, half-maximal cytotoxic concentration: 250 ug/mL
Beside the measured number, compound 4's estimate is 1.7-fold (0.22 log units) below it; measured number inside the range.
By their numbers in this assay, from the lowest: compound 1; then compounds 4, 3 and 2 (each within the scatter of the next).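

In this assay, for the compounds shown here, 4-(trifluoromethyl)phenyl in place of 2-nitrophenyl gives (a 1.0-fold lower number from compound 3 to compound 4 (0.01 log units; within the scatter)), and in place of 2-chlorophenyl it gives (a 1.3-fold lower number from compound 2 to compound 4 (0.12 log units; within the scatter)), so three different groups on this carbon with a double bond to nitrogen cannot be told apart, where the earlier compounds offered only two. Only 2,4-dichlorophenyl stands apart (a 4.4-fold higher number from compound 1 to compound 4 (0.65 log units; beyond the scatter)). Nothing on hand explains this pattern. From the compounds shown here alone, it remains open whether an amine or a carboxylic acid on the phenyl ring would stay with compound 2, compound 3 and compound 4 or fall nearer compound 1.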